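Changing the end group of the best chain compound

A few compounds are considered here, and "the series" means these few. Any claim that something is new, unique, unknown or untested is made for them only; others in the source may bear on it.

Measured so far in a functional assay on Hep 3B2 cells (Homo sapiens) for inhibition, read by MTT assay, with a stated time of 72 h; a higher number here means a weaker inhibitor, a lower number a stronger inhibitor
- compound 1 `Nc1nc2cc(-c3nn(CCCCC(=O)NO)c4ncnc(N)c34)ccc2o1` gives 33700 nM
- compound 2 `Nc1nc2cc(-c3nn(CCCCCC(=O)NO)c4ncnc(N)c34)ccc2o1` gives 34200 nM
- compound 3 `Nc1nc2cc(-c3nn(CCCCCCCCC(=O)NO)c4ncnc(N)c34)ccc2o1` gives 8890 nM

Compound 3 has the lowest number of the three and is the strongest inhibitor here, as both steps to it lie beyond the scatter (a 3.8-fold lower number from compound 1 to compound 3 (0.58 log units; beyond the scatter) and a 3.8-fold lower number from compound 2 to compound 3 (0.59 log units; beyond the scatter)). The next compound is compound 4 `CNC(=O)CCCCCCCn1nc(-c2ccc3oc(N)nc3c2)c2c(N)ncnc21`, and the change is this: methylcarbamoyl in place of (hydroxycarbamoyl)methyl on a saturated chain carbon, seven bonds along the chain from an aromatic nitrogen (methylcarbamoyl in place of (hydroxycarbamoyl)methyl). The measured steps bear on this only in part. All three compounds carry the hydroxycarbamoyl end and differ in chain length, and the longer chain gave the lower number only for compound 3, since compound 1 and compound 2 do not separate (a 1.0-fold higher number from compound 1 to compound 2 (0.01 log units; within the scatter)). Within the data shown here, no measured compound lacks that end, so its loss remains untested. A move back toward the weaker pair is expected, with the estimated size being a 3.4-fold higher number from compound 3 to compound 4 (0.53 log units; beyond the scatter) (a weaker inhibitor). Compound 4 is estimated at 30000 nM (range 9000 nM to 100000 nM).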

Compound 4, half-maximal inhibitory concentration: 10300 nM
Estimate against measurement, compound 4: 2.9-fold (0.46 log units) above, within the range that was stated.
By their numbers in this assay, from the lowest: compounds 3 and 4 (each within the scatter of the next); then compounds 1 and 2 (each within the scatter of the next).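

In this assay, the hydroxycarbamoyl end can be replaced by a methylcarbamoyl end, seven bonds along the chain from an aromatic nitrogen, with no readable change, as shown by a 1.2-fold higher number from compound 3 to compound 4 (0.06 log units; within the scatter). At this chain length, then, the low number does not depend on the hydroxycarbamoyl end, and compound 4 also stays clear of the shorter hydroxycarbamoyl compounds, with a 3.3-fold lower number from compound 1 to compound 4 (0.51 log units; beyond the scatter) and a 3.3-fold lower number from compound 2 to compound 4 (0.52 log units; beyond the scatter), although these two steps change the chain and the end together. Nothing measured here explains why the two ends match.

Still open, on these data alone, is whether a methylcarbamoyl end would also match the hydroxycarbamoyl end on the shorter chains of compound 1 and compound 2. As far as these compounds go, it is also open whether a carboxylic acid, an amine or a longer chain at this place would give a similar number.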